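Primary Amide Replaces Methoxyazetidine on the Acrylamide Carbonyl

The source may hold more compounds than are shown below. What is called first, only, known or untested is meant among the compounds shown, and "the series" means these compounds.

Of the compounds shown here, three sharing one core have been measured in a functional assay on HCT-116 cells (Homo sapiens) for inhibition, read by MTT assay, with a stated time of 72 h; a higher number here means a weaker inhibitor of growth, a lower number a stronger inhibitor of growth. Compound 1 `CN1CCN(C(=O)/C=C/c2ccncc2-c2ccc3ccccc3c2)CC1` carries a 4-methylpiperazin-1-yl group on the carbonyl carbon. In this assay compound 1 gives > 30000 nM, which is a limit of the assay and not a number. Compound 2 `O=C(O)/C=C/c1ccncc1-c1ccc2ccccc2c1` carries a hydroxy group in that position. Compound 2 likewise gives only a limit, > 30000 nM. Compound 3 `COC1CN(C(=O)/C=C/c2ccncc2-c2ccc3ccccc3c2)C1` carries 3-methoxyazetidin-1-yl. Compound 3 also sits at a limit, > 30000 nM. Hence (the limit of > 30000 nM in this assay, at which 3 of the 3 values shown sit), and the steps a step that the two limits leave unreadable from compound 1 to compound 2, a step that the two limits leave unreadable from compound 1 to compound 3 and a step that the two limits leave unreadable from compound 2 to compound 3 cannot be sized. Compound 3 therefore stands at the limit alongside the other two, with no order among them.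

Compound 4 `NC(=O)/C=C/c1ccncc1-c1ccc2ccccc2c1` differs from compound 3 in one place: amino in place of 3-methoxyazetidin-1-yl on a carbonyl carbon. Every exchange of the group on the carbonyl carbon measured so far has left the value at the limit, so no step beyond the scatter is expected from compound 3 to compound 4, and the most likely outcome is another limit rather than a number. The expected value for compound 4 is 40000 nM, within 10000 nM and 160000 nM. The step that the limit leaves unreadable from compound 3 to compound 4 is thus expected to be negligible.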

Compound 4, concentration for 50% growth inhibition: 12100 nM
The estimate for compound 4 lay 3.3-fold (0.52 log units) above the measured number; the measured number falls inside the stated range.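

The place on the carbonyl carbon is not silent in this assay: amino brings an at least 2.4-fold lower number from compound 3 to compound 4 (0.39 log units; beyond the scatter), an at least 2.4-fold lower number from compound 2 to compound 4 (0.39 log units; beyond the scatter) and an at least 2.4-fold lower number from compound 1 to compound 4 (0.39 log units; beyond the scatter). Of the four groups shown on this carbon, only amino gives a readable number, so an exchange here can shift growth inhibition, something the three earlier compounds could not show, and amino differs in this from a hydroxy group as well as from both ring-bearing amines. Each of these steps gives only a lower bound on the true size, and the steps among compound 1, compound 2 and compound 3 still cannot be read, because those three compounds rest at a limit: the limit of > 30000 nM in this assay, at which 3 of the 4 values shown sit.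

With a single readable compound, the shared core offers no series in which to size further exchanges at this place. On these data alone, whether a methylamino or a dimethylamino group on the carbonyl carbon would keep a readable number remains open, and so does whether the gain belongs to amino alone or extends to other small amines.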